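Moving the Ring Attachment Point on a Piperidine

The source may hold more compounds than are shown below. What is called first, only, known or untested is meant among the compounds shown, and "the series" means these compounds.

Three compounds share one core and differ only in the group on a saturated chain carbon, two bonds along the chain from an amine nitrogen. Compound 1 `CN1CCN(CCCN(C[C@H]2Cc3ccccc3CN2)[C@H]2CCCc3cccnc32)CC1` gives 53% in an ADME assay on microsomes from liver (Mus musculus) for metabolic stability, read by LC-MS, with a stated time of 10 min, tested at 0.5 uM; a higher number here means that more of the compound is left, a lower number that less of the compound is left. Compound 2 `CC(C)N1CCN(CCCN(C[C@H]2Cc3ccccc3CN2)[C@H]2CCCc3cccnc32)CC1` gives 58% in this assay, and a number 5 percentage points higher from compound 1 to compound 2 (within the scatter). Compound 3 `c1ccc2c(c1)CN[C@@H](CN(CCC1CCNCC1)[C@H]1CCCc3cccnc31)C2` gives 32% in this assay, the lowest of the three: a number 21 percentage points lower from compound 1 to compound 3 (beyond the scatter), and a number 26 percentage points lower from compound 2 to compound 3 (beyond the scatter).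

Compound 4 `c1ccc2c(c1)CN[C@@H](CN(CC[C@@H]1CCCNC1)[C@H]1CCCc3cccnc31)C2` is not yet measured. It carries the same atoms as compound 3, joined differently: piperidin-3-yl in place of piperidin-4-yl on a saturated chain carbon, two bonds along the chain from an amine nitrogen. Going by the values given here, none of the measured steps bears directly on this change; each of them swapped a piperidine for a piperazine bearing a further carbon, while here only the point of attachment on the piperidine moves. The two measured steps beyond the scatter are modest and concern a different kind of change, so no guide to the direction exists. Compound 4 is therefore expected to stay near compound 3, no change at the digits printed from compound 3 to compound 4 (within the scatter), with an estimate of 32% in this assay, ranging from 15% to 50%.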

Compound 4, percent of the compound remaining: 23%
Compound 4: middle estimate off by 9 percentage points, on the high side; measured number inside the range.
By their numbers in this assay, from the lowest: compounds 4 and 3 (each within the scatter of the next); then compounds 1 and 2 (each within the scatter of the next).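

Moving the attachment point is the first change here that keeps the ring a piperidine, and in this assay it gives a number 9 percentage points lower from compound 3 to compound 4 (within the scatter) so the shift from piperidin-4-yl to piperidin-3-yl has no readable effect at this position. Going by these compounds alone, the two piperazine compounds stay apart from this new piperidine, with a number 30 percentage points lower from compound 1 to compound 4 (beyond the scatter) and a number 35 percentage points lower from compound 2 to compound 4 (beyond the scatter) so across these four compounds the numbers divide by the type of ring on the chain, and no compound goes against that division. Nothing measured here offers a reason for these numbers.

Still open, as far as these compounds go, is whether a methyl or isopropyl group on the piperidine nitrogen of compound 4 would bring its number towards those of the piperazines. Also open, from the compounds shown here alone, is where a piperidin-2-yl group would fall, and whether the opposite configuration at the stereocentre of piperidin-3-yl would read the same.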